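The source may hold more compounds than are shown below. What is called first, only, known or untested is meant among the compounds shown, and "the series" means these compounds.

Of the compounds shown here, two have been read so far in an ADME assay on J774 cells (Mus musculus) for cytotoxicity, read by MTT assay, with a stated time of 24 h (on this read-out higher numbers stand for weaker inhibition and lower numbers for stronger inhibition), compound 1 (`Cc1c([N+](=O)[O-])cc(C(=O)N[C@H](C)c2ccc(F)cc2)cc1[N+](=O)[O-]`) and compound 2 (`Cc1ccc([C@@H](C)NC(=O)c2cc([N+](=O)[O-])cc([N+](=O)[O-])c2)cc1`). Compound 1 gives > 57600 nM as a limit of the assay, not a number. Compound 2 gives > 60700 nM as a limit as well, not a number. Among the measured compounds shown here, compound 2 therefore stands only as a limit, and the one other value beside it is also a limit, so no order can be drawn between the two. For the measured compounds named here, no step between measured compounds is available to size a change from.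

Compound 3 (`C[C@@H](NC(=O)c1cc([N+](=O)[O-])cc([N+](=O)[O-])c1)c1ccccc1`) is still to be measured in this assay. Compared with compound 2 it has hydrogen in place of methyl on an aromatic carbon, para to a large group, so that 4-methylphenyl becomes phenyl (hydrogen in place of methyl on an aromatic carbon). No shift beyond the usual scatter is expected, in either direction. This expectation rests on compound 2, with its limit of > 60700 nM in this series. The expected change, a step that the limit leaves unreadable from compound 2 to compound 3 as estimated, stays within the scatter. Compound 3 is expected to be reported as a limit too. For compound 3 the estimate is 63000 nM with an expected range from 30000 nM to 130000 nM in this assay.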

Compound 3, half-maximal inhibitory concentration: > 63400 nM
Compound 3 was reported as a limit; the forecaster's own chance of this, stated with the estimate: 80%; middle value at least 1.0-fold (0.00 log units) away from the limit.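

In this assay, among the compounds shown here, compound 2 and compound 3 both stand only as limits of the assay, so no step between them can be read. The compounds shown leave open where any of the three would give an actual number, and whether hydrogen in place of methyl on an aromatic carbon changes that number at all.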